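The compounds below may be only part of what the source reports. "The series", "measured", "known", "first", "only" and "open" are said of these compounds alone.

Compound 1 `COc1ccc(-c2c(C)sc3c(N4CC[C@@H](NC(C)=O)C4)nc(C)nc23)cc1OC`, compound 2 `COc1ccc(-c2c(C)nc3c(N4CC[C@@H](NC(=O)C(F)(F)F)C4)cc(C)nn23)cc1OC` and compound 3 `COc1ccc(-c2c(C)nc3c(N4CC[C@@H](NS(=O)(=O)C(C)C)C4)cc(C)nn23)cc1OC` form the measured set. In an ADME assay on microsomes from liver (Homo sapiens) for metabolic stability, read by LC-MS, with NADPH named in the record, with a stated time of 60 min, tested at 1 uM, in the absence of a further agent (a higher number here means that more of the compound is left, a lower number that less of the compound is left), compound 1 gives > 95%, which is a limit of the assay. Compound 2 gives > 95%, likewise a limit. Compound 3 gives > 95%, again a limit. The step that the two limits leave unreadable from compound 2 to compound 3 is therefore unreadable, since (the limit of > 95% in this assay, at which 3 of the 3 values shown sit). Compound 4 `COc1ccc(-c2c(C)nc3c(N4CC[C@@H](NS(N)(=O)=O)C4)cc(C)nn23)cc1OC` differs from compound 3 by amino in place of isopropyl on a sulfonyl sulfur. Within the data shown here, the only measured step at a comparable place is the unreadable one from compound 2 to compound 3, which says no more than that both ends sit at the limit. With every value at the limit, compound 4 is expected to remain there as well, and the step of a number no higher from compound 3 to compound 4 (the limit leaves the size open) is estimated as none beyond the scatter. For compound 4 the estimate is 95%, between 85% and 100%.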

Compound 4, percent of the compound remaining: > 95%
Compound 4 ended at the assay's limit (the forecaster's own chance of this, stated with the estimate: 80%); the middle value lies on the limit itself.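

The steps among compound 2, compound 3 and compound 4 cannot be read in this assay: the limit of > 95% in this assay, at which 4 of the 4 values shown sit.

The compounds shown leave open whether isopropylsulfonyl, sulfamoyl and (trifluoromethyl)carbonyl on an amine nitrogen differ at all in the percent of compound remaining.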